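This account rests on a few compounds, and the source may have more. Where it says the series, first, only, none or still open, it means among the compounds named here.

Of the compounds shown here, three of one series have so far been tested in a functional assay on A549 cells (Homo sapiens) for cytotoxicity, read by MTT assay, with a stated time of 24 h; on this read-out higher numbers stand for weaker inhibition and lower numbers for stronger inhibition. Compound 1 `C=CC1=C(C(=O)NCCC)C(c2ccc(F)cc2)OC1` reaches only the limit of the assay, giving > 100000 nM. Compound 2 `C=CC1=C(C(=O)O)C(c2ccc(F)cc2)OC1`, in which the propylamino group is replaced by hydroxy on the carbonyl carbon, likewise gives only the limit, > 100000 nM. The step that the two limits leave unreadable from compound 1 to compound 2 therefore cannot be read, as both ends are limits. Compound 3 `C=CC1=C(C(=O)NCCC)C(c2ccc(Cl)c(Cl)c2)OC1` also stands at the limit, with > 100000 nM. Going by the values given here, all three values sit at the limit of > 100000 nM in this assay, at which 3 of the 3 values shown sit, so no measured step in this assay has a readable size.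

Compound 4 `C=CC1=C(C(=O)Nc2ccccc2OC)C(c2ccc(Cl)c(Cl)c2)OC1` differs from compound 3 by 2-methoxyphenyl in place of propyl on an amide-type nitrogen. Among the compounds with values here, no measured step bears directly on this change, since the only step in this assay, from an amide to an acid, is unreadable. The account of compound 4 in this assay rests on compound 3 alone, which gives only a limit.

He would expect compound 4 to give 100000 nM, in a range from 30000 nM to 300000 nM, most likely again a limit rather than a number. The step he expects from compound 3 to compound 4 is a number no higher from compound 3 to compound 4 (the limit leaves the size open), nothing beyond the scatter.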

Compound 4, half-maximal inhibitory concentration: > 100000 nM
Compound 4: no number, only a limit (the forecaster's own chance of this, stated with the estimate: 75%); the middle value sits exactly at the limit.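

Compound 3 and compound 4 both give only a limit in this assay, so no step between them can be read: the limit of > 100000 nM in this assay, at which 4 of the 4 values shown sit.

The compounds shown leave open whether any change to the shared core yields a number rather than a limit, and what the group on the amide-type nitrogen contributes.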